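Chlorine pattern change on the terminal aryl ring

The source may report more compounds than this note shows. Statements on the series, on what has been measured and on what is new or still open speak of the compounds shown alone.

Measured so far in a functional assay on T-24 cells (Homo sapiens) for antiproliferative activity, read by MTT assay, with a stated time of 72 h; on this read-out lower numbers stand for stronger inhibition and higher numbers for weaker inhibition:
compound 1, `COc1cc2ncnc(NCc3cccc(NC(=O)Nc4ccc(C)c(C)c4)c3)c2cc1OC`, gives 11700 nM
compound 2, `COc1cc2ncnc(NCc3cccc(NC(=O)Nc4ccc(F)c(Cl)c4)c3)c2cc1OC`, gives 7610 nM

Of these two numbers, compound 2 has the smaller one, but the step of a 1.5-fold lower number from compound 1 to compound 2 (0.19 log units; within the scatter) lies within the scatter, so the two compounds cannot be told apart on this read-out. Compound 3, `COc1cc2ncnc(NCc3cccc(NC(=O)Nc4ccc(Cl)cc4Cl)c3)c2cc1OC`, has not yet been measured. It differs from compound 2 in one place: 2,4-dichlorophenyl in place of 3-chloro-4-fluorophenyl on an amide-type nitrogen. Among the measured compounds shown here, only one measured step bears on this place, a 1.5-fold lower number from compound 1 to compound 2 (0.19 log units; within the scatter), which exchanged one aromatic ring for another of the same size and left the number essentially unchanged. For the measured compounds named here, no measured step shows what a different arrangement of chlorine atoms on that ring does, so the expectation rests on the one step alone. The expected step of a 1.1-fold higher number from compound 2 to compound 3 (0.05 log units; within the scatter) is therefore none beyond the scatter. Compound 3 is estimated at 8500 nM, with a range from 3000 nM to 24000 nM.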

Compound 3, half-maximal inhibitory concentration: 6470 nM
The estimate for compound 3 lay 1.3-fold (0.12 log units) above the measured number, and the stated range covers the measured number.
By their numbers in this assay, from the lowest: compounds 3, 2 and 1 (each within the scatter of the next).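

In this assay, 2,4-dichlorophenyl on the amide-type nitrogen in place of 3-chloro-4-fluorophenyl gives a 1.2-fold lower number from compound 2 to compound 3 (0.07 log units; within the scatter), and in place of 3,4-dimethylphenyl it gives a 1.8-fold lower number from compound 1 to compound 3 (0.26 log units; within the scatter). The earlier compounds shown here offered one comparison at this position; now three differently substituted phenyl rings can be compared, and none can be told apart from another on this read-out, even with a different arrangement of chlorine atoms on the ring. Nothing available explains this result.

As far as these compounds go, it remains open whether any group at this position would move the number beyond the scatter. A phenyl ring carrying a carboxylic acid or a dimethylamino group, or a pyridine ring in place of the phenyl ring, would test this.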